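The compounds below may be only part of what the source reports. "The series", "measured", "known", "first", "only" and "open" are said of these compounds alone.

Working notes on the series.

Compound 3 `Cc1c(Cc2ccccc2S(=O)(=O)C2CCCCC2)c2c(n1CC(=O)O)CCNC2=O` gives 28 nM in a functional assay on CHO.K1 cells for antagonist activity at prostaglandin D2 receptor 2 (Homo sapiens), read by GTPgammaS binding, with a stated time of 1 h; a lower number here means a stronger inhibitor, a higher number a weaker inhibitor. Within this set of three, compound 3 has the highest number, with compound 1 `Cc1c(Cc2ccccc2S(=O)(=O)c2ccccc2F)c2c(n1CC(=O)O)CCNC2=O` at 3.6 nM and compound 2 `Cc1c(Cc2ccccc2S(=O)(=O)c2ccc(F)cc2)c2c(n1CC(=O)O)CCNC2=O` at 3.3 nM both lower; the two aryl sulfonyl analogues sit close together, as the step of a 1.1-fold lower number from compound 1 to compound 2 (0.04 log units; within the scatter) shows.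

The next step goes from compound 3 to compound 4 `Cc1c(Cc2ccccc2Oc2ccccc2)c2c(n1CC(=O)O)CCNC2=O`: phenoxy in place of cyclohexylsulfonyl on an aromatic carbon. Two parts of this change can be separated. The exchange of a six-membered non-aromatic ring for a six-membered aromatic ring is covered in reverse by a 7.8-fold higher number from compound 1 to compound 3 (0.89 log units; beyond the scatter) and an 8.5-fold higher number from compound 2 to compound 3 (0.93 log units; beyond the scatter), so restoring an aromatic ring on its own would be expected to lower the number by a comparable, modest margin. The loss of the sulfonyl in favour of a single oxygen link is not covered by any measured pair, and nothing here indicates its size or direction. The expectation is therefore a modest move down, with wide uncertainty around it, and the step of a 2.3-fold lower number from compound 3 to compound 4 (0.37 log units; beyond the scatter) is taken as the estimate.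

Compound 4 is thus expected at 12 nM, with a range of 3 nM to 60 nM.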

Compound 4, half-maximal inhibitory concentration: 530 nM
The estimate for compound 4 lay 44-fold (1.65 log units) below the measured number; measured number above the stated range.
By their numbers in this assay, from the lowest: compounds 2 and 1 (each within the scatter of the next); then compound 3; then compound 4.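

In this assay, the aromatic ring of the phenoxy group does not by itself hold the number low at this aromatic carbon, ortho to a large group: going from a sulfonyl-linked aryl group to phenoxy gives the largest steps in the series (a 160-fold higher number from compound 2 to compound 4 (2.21 log units; beyond the scatter) and a 150-fold higher number from compound 1 to compound 4 (2.17 log units; beyond the scatter)), although each of these compounds carries a six-membered aromatic ring there. Even the cyclohexylsulfonyl group, the weakest of the three sulfonyl groups so far, keeps the number well under that of the phenoxy compound (a 19-fold higher number from compound 3 to compound 4 (1.28 log units; beyond the scatter)), so all three sulfonyl compounds lie below compound 4, and the earlier finding that an aromatic ring on the sulfonyl gives a lower number than cyclohexyl does not carry over to this oxygen-linked ring. No measurement available here bears on the reason for this rise.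

Still open, from the compounds shown here alone, is whether a cyclohexyloxy group would fall further than phenoxy or match it, which would show if the ring preference survives with the oxygen link. Also open, going by these compounds, is where an unsubstituted phenylsulfonyl, a phenylthio group, a benzoyl group or an anilino amine link would fall between the sulfonyl compounds and compound 4.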